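The source may hold more compounds than are shown below. What is called first, only, known or untested is meant among the compounds shown, and "the series" means these compounds.

Compounds measured so far in an ADME assay on PC-3 cells (Homo sapiens) for cytotoxicity, read by WST assay, tested at 100 uM; a higher number here means more inhibition at the concentration tested (going by the name of the read-out), a lower number less inhibition:
- compound 1 `O=C(Nc1cccc(N2CCCC2=O)c1)C1CCCN(C(=O)c2cc(C(F)(F)F)cc(C(F)(F)F)c2)C1` gives 0%
- compound 2 `O=C(Nc1cccc([N+](=O)[O-])c1)C1CCCN(C(=O)c2cc(C(F)(F)F)cc(C(F)(F)F)c2)C1` gives 9%
- compound 3 `O=C(Nc1cccc(S(=O)(=O)N2CCCC2)c1)C1CCCN(C(=O)c2cc(C(F)(F)F)cc(C(F)(F)F)c2)C1` gives 0%

Compound 3 stands level with compound 1 at the digits given, the two together the lowest of the three numbers; compound 2 sits a little higher, but a number 9 percentage points lower from compound 2 to compound 3 (within the scatter) and a number 9 percentage points higher from compound 1 to compound 2 (within the scatter) are both within the scatter, so the three compounds are not separated in this assay.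

The next compound, compound 4 `Cc1nc(-c2cccc(NC(=O)C3CCCN(C(=O)c4cc(C(F)(F)F)cc(C(F)(F)F)c4)C3)c2)cs1`, is a further variation at the same position of the shared core: 2-methyl-1,3-thiazol-4-yl in place of (pyrrolidin-1-yl)sulfonyl on an aromatic carbon

Going by the values given here, the steps that bear on this are the two changes already made at this aromatic carbon, no change at the digits printed from compound 1 to compound 3 (within the scatter) and a number 9 percentage points lower from compound 2 to compound 3 (within the scatter); neither moved the read-out beyond the scatter, and nothing else in the set varies. The expectation is therefore that the exchange for 2-methyl-1,3-thiazol-4-yl also leaves this assay unchanged, with a number 3 percentage points higher from compound 3 to compound 4 (within the scatter) expected to lie within the scatter. Compound 4 is estimated at 3%, with a range of 0% to 15%.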

Compound 4, a percentage reported as inhibition, at one concentration (the size of the read-out at that concentration, not a potency): 1%
Compound 4: middle estimate off by 2 percentage points, on the high side; the range from low to high includes it.
By their numbers in this assay, from the lowest: compounds 1, 3, 4 and 2 (each within the scatter of the next).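

In this assay, going by these compounds alone, the step of a number 1 percentage points higher from compound 3 to compound 4 (within the scatter) stands with a number 1 percentage points higher from compound 1 to compound 4 (within the scatter) and a number 8 percentage points lower from compound 2 to compound 4 (within the scatter) as the first reading for an aromatic ring at this aromatic carbon. The position now carries 2-methyl-1,3-thiazol-4-yl, a five-membered aromatic ring with 2 hetero atoms, alongside nitro and the two groups with non-aromatic five-membered rings, and none of the four compounds is separated from another in this read-out. No measured evidence here accounts for this flat read-out.

Still open, on these data alone, is whether an amine, a carboxylic acid or a longer alkyl chain at this aromatic carbon would give a number beyond the scatter. Also open, as far as these compounds go, is whether replacing a trifluoromethyl group elsewhere on the shared core with a chlorine or a methoxy group would move the read-out.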